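A few compounds are considered here, and "the series" means these few. Any claim that something is new, unique, unknown or untested is made for them only; others in the source may bear on it.

Compound 1 `CCCCCNC(=O)/N=C(\N)NCCCc1sc(N)nc1C`: 0.78
Compound 2 `Cc1nc(N)sc1CCCN/C(N)=N/C(=O)NC(c1ccccc1)C(C)C`: 1.04
Compound 3 `Cc1nc(N)sc1CCCN/C(N)=N/C(=S)N[C@@H](C)c1ccccc1`: 0.65

In a functional assay on Right cardiac atrium for agonist activity at histamine H2 receptor (Cavia porcellus), with a stated time of 30 min, in the presence of a further agent that is not named here (on this read-out higher numbers stand for larger maximal responses and lower numbers for smaller maximal responses), compound 1 gives 0.78, the second highest of the three values. Compound 3 sits nearest, its value lower by more than the scatter, while compound 2 lies furthest, its value higher by more than the scatter. Compound 4 `Cc1nc(N)sc1CCCN/C(N)=N/C(=O)NC(C)c1cccs1` has not been measured in this assay. It differs from compound 1 by 1-(thiophen-2-yl)ethyl in place of pentyl on an amide-type nitrogen. Among the measured compounds shown here, no step between measured compounds covers this exchange, so the expectation rests on the spread alone: compound 2, which also carries a branched ring-bearing group on that nitrogen, reaches 1.04. The step a number 0.12 higher from compound 1 to compound 4 (beyond the scatter) is therefore expected to be modest and upward, and compound 4 is estimated at 0.9, between 0.7 and 1.05.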

Compound 4, intrinsic activity: the largest response reached, as a fraction of the reference agonist's: 0.88
Beside the measured number, compound 4's estimate is 0.020 above it, and the stated range covers the measured number.
By their numbers in this assay, from the lowest: compound 3; then compounds 1 and 4 (each within the scatter of the next); then compound 2.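

In this assay, putting 1-(thiophen-2-yl)ethyl in place of pentyl on an amide-type nitrogen gives a number 0.10 higher from compound 1 to compound 4 (within the scatter), so this position accepts a plain chain or a group carrying a five-membered aromatic ring without a difference the measurement can separate. No measured information on the two groups is available to explain this result. Still open, as far as these compounds go, is whether a longer chain such as octyl, or 1-(furan-2-yl)ethyl, on this nitrogen would give a maximal response clearly apart from these two.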